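This account rests on a few compounds, and the source may have more. Where it says the series, first, only, none or still open, it means among the compounds named here.

Of the compounds shown here, three have so far been tested in a functional assay on UACC-62 cells (Homo sapiens) for inhibition, read by sulforhodamine B assay, with a stated time of 48 h, tested at 10 uM; a higher number here means more inhibition of growth at the concentration tested, a lower number less inhibition of growth. Compound 1 `c1ccc(-c2nc3sc(-c4ccccc4)cn3n2)cc1` gives 33% there, compound 2 `CC(=O)c1ccc(NC(=O)Cn2nc(-c3ccc(Cl)cc3)nc2N)cc1` gives 6.29%, and compound 3 `COc1ccc(-c2nc3sc(-c4ccc(Cl)cc4)cn3n2)cc1` gives 31.4%. Compound 3 thus ranks second highest of the three numbers, though its gap to compound 1 is within the scatter, while its gap to compound 2 is beyond it. Compound 4 `Clc1ccc(-c2cn3nc(-c4ccccc4)nc3s2)cc1` remains to be measured. Relative to compound 3 it shows (hydrogen in place of methoxy on an aromatic carbon). For the measured compounds named here, no step between two measured compounds differing in one place is known, so the weight of this change has no direct precedent. Compound 1, which also carries no methoxy, gives 33%, a value within the scatter of compound 3. The change is therefore expected to bring a step of a number 0.4 percentage points lower from compound 3 to compound 4 (within the scatter), not beyond the scatter in either direction. Compound 4 is estimated at 31%, with a range from 18% to 44%.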

Compound 4, percent growth inhibition at one concentration: 18%
Compound 4: the middle estimate sits 13 percentage points above what was measured; measured number inside the range.
By their numbers in this assay, from the lowest: compound 2; then compound 4; then compounds 3 and 1 (each within the scatter of the next).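

In this assay, this aromatic carbon proves to matter once the chloro group is present: hydrogen in place of methoxy brings a number 13.4 percentage points lower from compound 3 to compound 4 (beyond the scatter). Chloro in place of hydrogen, without a methoxy on the other ring, likewise brings a number 15 percentage points lower from compound 1 to compound 4 (beyond the scatter), so the chloro group alone does not keep the number up. No measurement is at hand that explains either step. From the compounds shown here alone, it remains open what methoxy does on the core without the chloro group, and whether an amine or an ethoxy chain at this carbon would act like methoxy.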